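The source may report more compounds than this note shows. Statements on the series, on what has been measured and on what is new or still open speak of the compounds shown alone.

Three compounds share the same core and differ only in the length of the saturated chain that carries a phenoxy group. Compound 1 `O=C(O)c1csc([C@H]2CC[C@@H]3[C@@H](CCCCCOc4ccccc4)[C@H](O)C[C@@H]3O2)n1` has the longest chain; in a functional assay on CHO cells for agonist activity at prostaglandin E2 receptor EP4 subtype (Homo sapiens), read by HTRF and cAMP accumulation, with a stated time of 30 min (on this read-out lower numbers stand for an effect already at smaller amounts and higher numbers for an effect only at larger amounts of compound), compound 1 gives "not determined" (no result reported), so it contributes no number. Compound 2 `O=C(O)c1csc([C@H]2CC[C@@H]3[C@@H](CCCOc4ccccc4)[C@H](O)C[C@@H]3O2)n1` has a shorter chain. In this assay compound 2 gives > 10000 nM, which is a limit of the assay rather than a measured number. Compound 2 therefore stands at the edge of what this assay can report: the limit of > 10000 nM in this assay, at which 1 of the 2 values shown sits. Compound 3 `O=C(O)c1csc([C@H]2CC[C@@H]3[C@@H](CCOc4ccccc4)[C@H](O)C[C@@H]3O2)n1` has not yet been measured in this assay. The change from compound 2 to compound 3 is phenoxy in place of phenoxymethyl on a saturated chain carbon, two bonds along the chain from a saturated ring carbon, that is, the chain is shortened once more. No measured step between two compounds exists here, so no size of effect has been shown for shortening this chain. With compound 2 already at the limit, compound 3 is expected to give 15000 nM, within 3000 nM to 100000 nM, in this assay. Expected is a step that the limit leaves unreadable from compound 2 to compound 3, most likely nothing beyond the scatter, with the outcome quite possibly another limit rather than a number.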

Compound 3, half-maximal effective concentration: > 10000 nM
Compound 3: no number, only a limit; the forecaster's own chance of this, stated with the estimate: 70%; the middle value lies beyond the limit too.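

Among these compounds, compound 2 and compound 3 both end at a limit of this assay rather than at a number, so no step between them can be read. The compounds shown leave open how much the length of the chain carrying the phenoxy group matters, and whether any length gives a measurable effect.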